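A Carbamate Group in Place of an Acyl Azide

A few compounds are considered here, and "the series" means these few. Any claim that something is new, unique, unknown or untested is made for them only; others in the source may bear on it.

Of the compounds shown here, three have been measured in a functional assay on Ehrlich cells (Mus musculus) for cytotoxicity, read by trypan blue exclusion, with a stated time of 2 h, tested at 1 ug/mL; a lower number here means a stronger effect, a higher number a weaker effect of the compound at the concentration tested. Compound 1 `N#Cc1c(N)[n+]([O-])c2ccc(Cl)cc2[n+]1[O-]` gives 100%, compound 2 `Cc1c(C(=O)N=[N+]=[N-])[n+]([O-])c2cc(Cl)ccc2[n+]1[O-]` gives 100%, and compound 3 `COc1ccc2c(c1)[n+]([O-])c(C(=O)N=[N+]=[N-])c(C)[n+]2[O-]` gives 94.5%. Compound 2 thus stands level with compound 1 at the digits shown, the two together the highest of the three numbers, and the step of a number 5.5 percentage points lower from compound 2 to compound 3 (within the scatter), a methoxy in place of chloro on an aromatic carbon, stays within the scatter. Compound 4 `Cc1c(NC(=O)OC(C)C)[n+]([O-])c2cc(Cl)ccc2[n+]1[O-]` differs from compound 2 by a group of 7 heavy atoms (4 carbon, 1 nitrogen, 2 oxygen; no ring) in place of a group of 5 heavy atoms (1 carbon, 3 nitrogen, 1 oxygen; no ring), on an aromatic carbon. For the measured compounds named here, no measured step touches this position, and the one known step is small, so no change beyond the scatter is expected in this assay. Compound 4 is therefore estimated at 95%, between 75% and 100%, an expected step of a number 5 percentage points lower from compound 2 to compound 4 (within the scatter).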

Compound 4, a percentage reported as activity, at one concentration (the size of the read-out at that concentration, not a potency): 100%
Estimate against measurement, compound 4: 5 percentage points below; the range from low to high includes it.
By their numbers in this assay, from the lowest: compounds 3, 1, 2 and 4 (each within the scatter of the next).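

Putting (isopropoxycarbonyl)amino in place of the acyl azide, on the aromatic carbon next to the ring nitrogen, gives in this assay no change at the digits printed from compound 2 to compound 4 (within the scatter) and so shows the first measured result at this position. For the compounds shown here, the acyl azide is therefore not the only group here that gives this reading, and neither group gives a lower number. Nothing at hand explains this result.

Open, going by these compounds, is whether a free amine or a carboxylic acid here would give a lower number, and whether a longer chain on the carbamate would.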